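Dropping a Chloro Group from the Core of Compound 2

A few compounds are considered here, and "the series" means these few. Any claim that something is new, unique, unknown or untested is made for them only; others in the source may bear on it.

Measured so far:
- compound 1, `ClCc1ccc(Cn2cnc3c(Cl)ncnc32)cc1`: 270 nM
- compound 2, `ClCc1ccccc1Cn1cnc2c(Cl)nc(Cl)nc21`: 1900 nM

Both compounds were tested in a functional assay on SF-295 cells (Homo sapiens) for cytotoxicity, read by sulforhodamine B assay, with a stated time of 48 h; on this read-out higher numbers stand for weaker inhibition of growth and lower numbers for stronger inhibition of growth. Compound 1 gives 270 nM, while compound 2 gives 1900 nM, the higher of the two numbers, and the gap between them is beyond the usual scatter. Compound 3, `ClCc1ccccc1Cn1cnc2c(Cl)ncnc21`, has not yet been measured. It differs from compound 2 in one place: hydrogen in place of chloro on an aromatic carbon, on an aromatic carbon of a six-membered aromatic ring with 2 nitrogen, between two ring nitrogen atoms, meta to a chloro group. After this change the core of compound 3 matches the core of compound 1, although the chloromethyl group sits differently on the benzyl ring. Compound 3 is therefore expected to give a lower number than compound 2, a step of a 3.2-fold lower number from compound 2 to compound 3 (0.50 log units; beyond the scatter) in this assay, with an estimate of 600 nM, between 200 nM and 2000 nM.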

Compound 3, concentration for 50% growth inhibition: 10500 nM
The estimate for compound 3 lay 18-fold (1.24 log units) below the measured number; the whole stated range lies below it.
By their numbers in this assay, from the lowest: compound 1; then compound 2; then compound 3.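

In this assay, putting hydrogen in place of chloro on the aromatic carbon between two ring nitrogen atoms gives a 5.5-fold higher number from compound 2 to compound 3 (0.74 log units; beyond the scatter), so in this series that chloro group goes with stronger inhibition of growth rather than weaker. Sharing a core with compound 1 also does not bring the same number: compound 1 gives 270 nM, while compound 3, which differs from it in where the chloromethyl group sits on the benzyl ring, gives 10500 nM. No measurement available here bears on why this step runs in this direction.

Going by these compounds, whether an amine or a methoxy group on that same carbon would give a number closer to that of compound 2 stays open. Also open, on these data alone, is whether removing this chloro group would have the same effect with the chloromethyl group placed as in compound 1.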